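Trimming the isobutoxy chain to methoxy on a shared core

The compounds below may be only part of what the source reports. "The series", "measured", "known", "first", "only" and "open" are said of these compounds alone.

Of the compounds shown here, three sharing one core have been tested in a functional assay on A549 cells (Homo sapiens) for cytotoxicity, with a stated time of 48 h; a higher number here means a weaker inhibitor, a lower number a stronger inhibitor. Compound 1 `COc1cccc2c(=O)cc(/C=C/[S+](C)[O-])oc12` gives 2200 nM. Compound 2 `C[S+]([O-])/C=C/c1cc(=O)c2cc(Cl)ccc2o1` gives 1700 nM. Compound 3 `CC(C)COc1ccc2oc(/C=C/[S+](C)[O-])cc(=O)c2c1` gives 1100 nM, the smallest of the three numbers, though the step of a 1.5-fold lower number from compound 2 to compound 3 (0.19 log units; within the scatter) lies within the scatter, and the gap between compound 1 and compound 3 lies within the scatter as well. So the three numbers cannot be told apart with confidence.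

Compound 4 `COc1ccc2oc(/C=C/[S+](C)[O-])cc(=O)c2c1` is not yet measured. It differs from compound 3 in one place: hydrogen in place of isopropyl on a saturated chain carbon bound to an oxygen on an aromatic ring. Among the compounds with values here, no measured step shortens an alkoxy chain in this way; the only step known, a 1.5-fold lower number from compound 2 to compound 3 (0.19 log units; within the scatter), swaps chloro for isobutoxy and stays within the scatter. Compound 1 carries a methoxy group elsewhere on the core and still gives 2200 nM, which suggests that alkoxy groups of either size leave the number in the same region.

The expected step of a 1.5-fold higher number from compound 3 to compound 4 (0.16 log units; within the scatter) is therefore small and could run either way. Compound 4 is estimated at 1600 nM, within a range of 700 nM to 3600 nM.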

Compound 4, half-maximal inhibitory concentration: 1600 nM
The estimate for compound 4 equals the measured number at the digits printed, within the range that was stated.
By their numbers in this assay, from the lowest: compounds 3, 4, 2 and 1 (each within the scatter of the next).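

In this assay trimming isobutoxy to methoxy, the first change made only to the length of this chain, gives a 1.5-fold higher number from compound 3 to compound 4 (0.16 log units; within the scatter) and so cannot be told apart from no change at all. Swapping chloro for methoxy gives a 1.1-fold lower number from compound 2 to compound 4 (0.03 log units; within the scatter) and is just as unreadable. Chloro, methoxy and isobutoxy at this one position therefore all lie within the scatter of each other, so this assay shows no preference among these three groups there.

Going by these compounds, whether a much longer chain, an amine or a carboxylic acid at this position would move the number beyond the scatter remains open. Nothing measured alongside these numbers offers an explanation for this result.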